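A few compounds are considered here, and "the series" means these few. Any claim that something is new, unique, unknown or untested is made for them only; others in the source may bear on it.

Measured compounds:
Compound 1, `N[C@@H]1CCN(c2cc3c(cc2F)c(=O)c(C(=O)O)cn3Cc2ccc(-c3ccccc3)cc2)C1`, in an assay on isolated protein for inhibition of DNA topoisomerase 1 (Homo sapiens), with a stated time of 15 min (on this read-out lower numbers stand for stronger inhibition and higher numbers for weaker inhibition), gives 63600 nM.
Compound 2, `COc1c(N2CC[C@@H](N)C2)c(F)cc2c(=O)c(C(=O)O)cn(Cc3ccc(-c4ccccc4)cc3)c12`, in this assay gives 92200 nM.
Compound 3, `CNCCCNc1c(F)cc2c(=O)c(C(=O)O)cn(Cc3ccc(-c4ccccc4)cc3)c2c1OC`, in this assay gives 101000 nM.

The three numbers all lie within the scatter of one another, so no order among them is claimed. The change from compound 2 to compound 1 is hydrogen in place of methoxy on an aromatic carbon; it made a step of a 1.4-fold lower number from compound 2 to compound 1 (0.16 log units; within the scatter). The two cores differ as (3-(methylamino)propyl)amino in place of 3-aminopyrrolidin-1-yl on an aromatic carbon, with a step of a 1.1-fold higher number from compound 2 to compound 3 (0.04 log units; within the scatter).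

Compound 4, `CNCCCNc1cc2c(cc1F)c(=O)c(C(=O)O)cn2Cc1ccc(-c2ccccc2)cc1`, is not yet measured. It differs from compound 3 by hydrogen in place of methoxy on an aromatic carbon. This is the same kind of change as from compound 2 to compound 1, not the same: in the earlier case the place is ortho to a 3-aminopyrrolidin-1-yl group, here it is ortho to a (3-(methylamino)propyl)amino group, while the rest of the place description agrees word for word. In this assay the step from compound 3 to compound 4 is expected to be a 1.4-fold lower number from compound 3 to compound 4 (0.15 log units; within the scatter), of about the same size as the earlier one, which rests on the single precedent a 1.4-fold lower number from compound 2 to compound 1 (0.16 log units; within the scatter) and on the closeness of compound 2 and compound 3 shown by a 1.1-fold higher number from compound 2 to compound 3 (0.04 log units; within the scatter). The estimate for compound 4 in this assay is 72000 nM, with a range from 35000 nM to 150000 nM expected to hold most repeat measurements.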

Compound 4, half-maximal inhibitory concentration: 63600 nM
Estimate against measurement, compound 4: 1.1-fold (0.05 log units) above; low and high end bracket the measured number.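

In this assay, hydrogen in place of methoxy on the core bearing (3-(methylamino)propyl)amino gives a 1.6-fold lower number from compound 3 to compound 4 (0.20 log units; within the scatter), and this agrees with the step seen on the core bearing 3-aminopyrrolidin-1-yl: the same change on two cores in this assay, a 1.4-fold lower number (0.16 log units; within the scatter) from compound 2 to compound 1 and a 1.6-fold lower number (0.20 log units; within the scatter) from compound 3 to compound 4, 1.1-fold (0.04 log units) apart, within the scatter of two such steps Read the other way, (3-(methylamino)propyl)amino in place of 3-aminopyrrolidin-1-yl on the core without methoxy gives no change at the digits printed from compound 1 to compound 4 (within the scatter), which likewise agrees with the step on the core with methoxy: the same change on two cores in this assay, a 1.1-fold higher number (0.04 log units; within the scatter) from compound 2 to compound 3 and no change at the digits printed (within the scatter) from compound 1 to compound 4, 1.1-fold (0.04 log units) apart, within the scatter of two such steps Both changes therefore carry between these two cores without any readable departure, but every step here lies within the scatter, so this is agreement among small steps: it does not establish that either change has an effect of its own, and it does not show how a step beyond the scatter would carry over, nor does it extend past these four compounds.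

As far as these compounds go, whether ethoxy or chloro in place of methoxy, or a longer chain in place of the two amine-bearing groups, would stay within the scatter remains open. Also open, from the compounds shown here alone, is whether a step beyond the scatter appears when a carboxamide replaces the carboxylic acid or a hydrogen replaces the fluoro group.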